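Imidazoline analogues at the alpha-2B receptor: a pyridyl replacement

The source may report more compounds than this note shows. Statements on the series, on what has been measured and on what is new or still open speak of the compounds shown alone.

Of the compounds shown here, two have been measured in an assay on CHO cells for displacement of a labelled ligand from Alpha-2B adrenergic receptor (Homo sapiens); on this read-out higher numbers stand for weaker inhibition and lower numbers for stronger inhibition. Compound 1 `CC(Oc1ccccc1-c1ccccc1)C1=NCCO1` gives 10000 nM in this assay. Compound 2 `CC(Oc1ccccc1-c1ccccc1O)C1=NCCN1`, which carries an imidazoline and a hydroxyl on its distal ring, gives 1000 nM, the lower of the two numbers, and its value sits a full order below that of compound 1, a gap that lies beyond the usual scatter. Within the data shown here, no single-change step links these two measured compounds.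

Compound 3 `CC(Oc1ccccc1-c1ccncc1)C1=NCCN1` has not yet been measured. Its change from compound 2 is pyridin-4-yl in place of 2-hydroxyphenyl on an aromatic carbon. The hydrogen-bond donor of compound 2 is thus lost while a ring nitrogen enters as acceptor.

Because compound 2 gives 1000 nM and the donor is lost, a modest weakening is expected, a 3.0-fold higher number from compound 2 to compound 3 (0.48 log units; beyond the scatter). Compound 3 is estimated at 3000 nM in this assay, within a range from 800 nM to 12000 nM.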

Compound 3, inhibition constant: 2690 nM
Compound 3: middle estimate off by 1.1-fold (0.05 log units), on the high side, within the range that was stated.
By their numbers in this assay, from the lowest: compound 2; then compound 3; then compound 1.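

In this assay, pyridin-4-yl in place of 2-hydroxyphenyl on an aromatic carbon gives a 2.7-fold higher number from compound 2 to compound 3 (0.43 log units; beyond the scatter), the first single-change step available in this series. At this position, a ring with a hydrogen-bond donor can give way to one with no donor and a ring nitrogen at the cost of only a modest change in the number. The change alters the ring atoms, the donor count and the heavy-atom count together, and no measurement at hand separates these or explains the step.

The compounds shown leave open how pyridin-3-yl, or a phenyl ring carrying an amine or a carboxylic acid, would read at this position. Compound 1 differs from compound 2 and compound 3 in more than one place, and so adds no single-change comparison.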